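Urea-to-amide change on a pyrazole series in PC-3 growth

The source may hold more compounds than are shown below. What is called first, only, known or untested is meant among the compounds shown, and "the series" means these compounds.

Measured so far:
compound 1 `COc1cc(-c2nn(-c3cccc(NC(=O)Nc4ccc(Cl)c(Cl)c4)c3)cc2-c2ccncc2)ccc1Cl`, 554 nM
compound 2 `O=C(Nc1cccc(-n2cc(-c3ccncc3)c(-c3ccc(Cl)c(O)c3)n2)c1)Nc1ccc(Cl)c(Cl)c1`, 834 nM

In a functional assay on PC-3 cells (Homo sapiens) for inhibition, read by sulforhodamine B assay, with a stated time of 48 h (on this read-out higher numbers stand for weaker inhibition of growth and lower numbers for stronger inhibition of growth), compound 1 gives 554 nM, the lower of the two numbers recorded; compound 2 gives 834 nM. Within the data shown here, the only step available, a 1.5-fold higher number from compound 1 to compound 2 (0.18 log units; within the scatter), is within the scatter, so the two compounds are not separated by this assay.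

Compound 3 `COc1cc(-c2nn(-c3cccc(NC(=O)c4ccc(Cl)c(C(F)(F)F)c4)c3)cc2-c2ccncc2)ccc1Cl` has not been measured. It differs from compound 1 by 4-chloro-3-(trifluoromethyl)phenyl in place of (3,4-dichlorophenyl)amino on a carbonyl carbon. Among the measured compounds shown here, no measured step touches this part of the molecule: the one step recorded concerns the methyl on the oxygen, and the urea linkage is the same in compound 1 and compound 2. There is therefore nothing in this assay that bears directly on the change.

For the measured compounds named here, with no comparable step to lean on, the expectation rests on compound 1 alone: compound 3 is estimated at 1100 nM, with a range of 300 nM to 4000 nM, that is, an expected step of a 2.0-fold higher number from compound 1 to compound 3 (0.30 log units; within the scatter), wide enough to cover no change as well as a moderate loss.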

Compound 3, concentration for 50% growth inhibition: 1290 nM
Compound 3: middle estimate off by 1.2-fold (0.07 log units), on the low side; the range from low to high includes it.
By their numbers in this assay, from the lowest: compounds 1, 2 and 3 (each within the scatter of the next, the first and the last beyond it).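

Among these compounds, the position on the carbonyl carbon gives the first step that clears the scatter in this assay: a 2.3-fold higher number from compound 1 to compound 3 (0.37 log units; beyond the scatter), a modest loss, with the amide compound 3 still giving 1290 nM, so a urea linkage is not needed for growth inhibition to be read in this assay. Among the compounds shown here, the single step bundles several changes, since the amino nitrogen and its hydrogen-bond donor leave while a trifluoromethyl group enters the aromatic ring, and the data cannot divide the loss among them. No measurement on hand speaks to why the number moves.

Going by these compounds, what stays open is which part of the change carries the step: (4-chloro-3-(trifluoromethyl)phenyl)amino on the same carbonyl carbon would keep the urea and change only the ring substituent, while 3,4-dichlorophenyl there would keep the ring and remove only the amino nitrogen. Also open, on these data alone, is whether a non-aromatic group at this position, such as a cyclohexyl ring or a morpholine, keeps any growth inhibition.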